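Moving the Trifluoromethyl on the Core of Compound 2

A few compounds are considered here, and "the series" means these few. Any claim that something is new, unique, unknown or untested is made for them only; others in the source may bear on it.

Of the compounds shown here, three have numbers so far. Compound 1 `COc1ccc(C2CC(=O)C(Br)=CO2)cc1` gives 69 uM in a functional assay on HT-29 cells (Homo sapiens) for inhibition, read by sulforhodamine B assay, with a stated time of 48 h; a higher number here means a weaker inhibitor of growth, a lower number a stronger inhibitor of growth. Compound 2 `O=C1C=CCC(/C=C/c2ccccc2)N1` gives 1200 uM in this assay. Compound 3 `O=C1C=CCC(/C=C/c2ccccc2C(F)(F)F)N1` gives 195 uM in this assay.

Compound 2 stands highest of the three numbers in this assay. Its nearest neighbour is compound 3, reached by a 6.2-fold lower number from compound 2 to compound 3 (0.79 log units; beyond the scatter), a modest step beyond the scatter. Compound 1, at 69 uM, lies furthest from compound 2, and with a different core it offers no single-point comparison.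

Compound 4 `O=C1C=CCC(/C=C/c2ccc(C(F)(F)F)cc2)N1` differs from compound 2 by one change: trifluoromethyl in place of hydrogen on an aromatic carbon. Going by the values given here, the only measured step that bears on it is a 6.2-fold lower number from compound 2 to compound 3 (0.79 log units; beyond the scatter), which adds the same group to the same ring at another position on the ring. On that basis a downward step of comparable size, a 4.8-fold lower number from compound 2 to compound 4 (0.68 log units; beyond the scatter), is expected for compound 4. Compound 4 is therefore estimated at 250 uM in this assay, with a range from 80 uM to 800 uM.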

Compound 4, concentration for growth inhibition (reported as GI): 139 uM
Estimate against measurement, compound 4: 1.8-fold (0.25 log units) above; measured number inside the range.
By their numbers in this assay, from the lowest: compounds 1, 4 and 3 (each within the scatter of the next, the first and the last beyond it); then compound 2.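

In this assay, going by these compounds alone, trifluoromethyl para to a group of 9 heavy atoms also lowers the number, by an 8.6-fold lower number from compound 2 to compound 4 (0.94 log units; beyond the scatter), so the drop on this ring is not confined to the single placement seen in compound 3. Compound 3 at 195 uM and compound 4 at 139 uM lie within the scatter of each other, so these two placements of the group cannot be told apart in this assay. Nothing available here accounts for the lowering of the number by either placement.

Trifluoromethyl is the only group shown on this ring, so it remains open whether a chlorine atom, a methoxy group or a carboxylic acid at the same position would lower the number as well. Compound 1 has a different core, which leaves open how any such ring change would read on it.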